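Hydroxamic acid series: cyano in place of aryl tert-butyl

A few compounds are considered here, and "the series" means these few. Any claim that something is new, unique, unknown or untested is made for them only; others in the source may bear on it.

Measured so far:
compound 1 `Cc1ccc(CN2CC=C(CCC(=O)NO)C2=O)cc1`, 4280 nM
compound 2 `CC(C)(C)c1ccc(CN2CC=C(CCC(=O)NO)C2=O)cc1`, 720 nM

In a functional assay on NUGC-3 cells (Homo sapiens) for inhibition, read by sulforhodamine B assay (on this read-out lower numbers stand for stronger inhibition of growth and higher numbers for weaker inhibition of growth), compound 1 gives 4280 nM and compound 2 gives 720 nM. Among the measured compounds shown here, compound 2 stands at the lower of the two numbers; the only measured step, a 5.9-fold lower number from compound 1 to compound 2 (0.77 log units; beyond the scatter), sets it apart from compound 1.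

Compound 3 `N#Cc1ccc(CN2CC=C(CCC(=O)NO)C2=O)cc1` has not yet been measured in this assay. It differs from compound 2 by cyano in place of tert-butyl on an aromatic carbon. For the measured compounds named here, no measured step involves a cyano group, so the change has no direct precedent. Going by the values given here, the one step available, a 5.9-fold lower number from compound 1 to compound 2 (0.77 log units; beyond the scatter), shows that the group of more heavy atoms gave the lower number, and the cyano group that enters has fewer heavy atoms than the tert-butyl it replaces. A rise in the number, beyond the scatter, is therefore expected, though its size is uncertain. For compound 3 the expected step is a 3.5-fold higher number from compound 2 to compound 3 (0.54 log units; beyond the scatter). Compound 3 is estimated at 2500 nM, within 800 nM to 8000 nM.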

Compound 3, concentration for 50% growth inhibition in the NUGC-3 assay: > 10000 nM
Compound 3 ended at the assay's limit (the forecaster's own chance of this, stated with the estimate: 5%); middle value at least 4.0-fold (0.60 log units) from the limit.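

In the NUGC-3 assay, cyano on this aromatic carbon gives an at least 13-fold higher number from compound 2 to compound 3 (1.14 log units; beyond the scatter) and an at least 2.3-fold higher number from compound 1 to compound 3 (0.36 log units; beyond the scatter), so it falls behind methyl as well as tert-butyl, and the count of heavy atoms alone does not order the three groups. In the NUGC-3 assay compound 3 reaches a limit of the assay, not a number: > 10000 nM. In a physicochemical assay for lipophilicity (a higher number here means a more lipophilic compound, a lower number a more polar compound), compound 2 gives 2.1 and compound 3 gives 0.197. The loss of growth inhibition on going to cyano comes with a drop in lipophilicity, though this single pair cannot show that the drop is the cause: the measured distribution coefficient of compound 2, 2.1, and of compound 3, 0.197, a number 1.90 log units lower (beyond the scatter)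

Open, going by these compounds, is whether a trifluoromethyl or a methoxy group on the same aromatic carbon would follow the trend in distribution coefficient or the cyano result. On these data alone, how far compound 3 lies past its limit also stays open.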